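A Methoxy Group on the Outer Ring of an Amidine

The compounds below may be only part of what the source reports. "The series", "measured", "known", "first", "only" and "open" are said of these compounds alone.

Compound 2 `N=C(N)c1ccc(-c2ccc(-c3ccccc3)s2)s1` gives 85.1% in an ADME assay on cells (Erythrocyte, Homo sapiens) for activation, read by hemolysis, with a stated time of 30 min, tested at 10 mM; on this read-out lower numbers stand for a weaker effect and higher numbers for a stronger effect at the one concentration tested. Among the compounds with values here, this places it highest of the two compounds measured so far; its neighbour, compound 1 `N=C(N)c1ccc(-c2ccc(-c3cc(Cl)cc(Cl)c3)s2)s1`, gives 17% in this assay, a gap well beyond the scatter. The next compound, compound 3 `COc1ccc(-c2ccc(-c3ccc(C(=N)N)s3)s2)cc1`, carries a single change on a six-membered aromatic ring of carbon only: methoxy in place of hydrogen on an aromatic carbon. Within the data shown here, no measured pair shows this change, so the expectation rests on compound 2 alone. The step of a number 25.1 percentage points lower from compound 2 to compound 3 (beyond the scatter) is expected to go downward, beyond the scatter. Compound 3 is therefore estimated at 60%, with a range from 25% to 95%.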

Compound 3, a percentage reported as activity, at one concentration (the size of the read-out at that concentration, not a potency): 92.7%
Compound 3: middle estimate off by 32.7 percentage points, on the low side; low and high end bracket the measured number.
By their numbers in this assay, from the lowest: compound 1; then compounds 2 and 3 (each within the scatter of the next).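

In this assay, putting methoxy in place of hydrogen gives a number 7.6 percentage points higher from compound 2 to compound 3 (within the scatter), so the two compounds cannot be told apart on this read-out. At this aromatic carbon, para to a large group, the added oxygen and carbon therefore leave the hemolysis reading without a measurable change. Nothing available here explains this result. As far as these compounds go, whether an amine or a carboxylic acid on the same carbon would also leave the reading unchanged remains open, as does the effect of methoxy elsewhere on this ring.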